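Chloro for Fluoro at Two Different Sites

The compounds below may be only part of what the source reports. "The series", "measured", "known", "first", "only" and "open" are said of these compounds alone.

Measured compounds:
- compound 1, `COc1cc(-c2nc(-c3ccccc3)[nH]c2-c2ccnc(NCCCNS(=O)(=O)c3ccc(Cl)cc3)n2)ccc1F`, 83100 nM
- compound 2, `COc1cc(-c2nc(-c3ccccc3)[nH]c2-c2ccnc(NCCCNS(=O)(=O)c3ccc(F)cc3)n2)ccc1F`, 3960 nM
- compound 3, `O=S(=O)(NCCCNc1nccc(-c2[nH]c(-c3ccccc3)nc2-c2ccc(F)c(O)c2)n1)c1ccccc1`, 9580 nM

In a functional assay on LOX IMVI cells (Homo sapiens) for cytotoxicity, read by MTT assay, with a stated time of 24 h (on this read-out higher numbers stand for weaker inhibition and lower numbers for stronger inhibition), compound 2 gives 3960 nM, compound 1 gives 83100 nM and compound 3 gives 9580 nM. Compound 1 and compound 2 share one core and differ only in the change (chloro in place of fluoro on an aromatic carbon), which produced a 21-fold higher number from compound 2 to compound 1 (1.32 log units; beyond the scatter). Compound 3 has a different core; how the two cores differ is not broken down here.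

Compound 4, `O=S(=O)(NCCCNc1nccc(-c2[nH]c(-c3ccccc3)nc2-c2ccc(Cl)c(O)c2)n1)c1ccccc1`, is not yet measured. It is made from compound 3 by chloro in place of fluoro on an aromatic carbon. This is the same kind of change as that from compound 2 to compound 1, but not the same: in compound 4 the new chloro sits ortho to a hydroxy group and para to a large group, whereas in compound 1 it sits only para to a large group, on a different ring of the molecule.

Among the measured compounds shown here, because the one measured example of this kind of change, a 21-fold higher number from compound 2 to compound 1 (1.32 log units; beyond the scatter), gave a large loss, a weakening is expected for compound 4 as well, though a smaller and less certain one, since the surroundings of the change differ. The estimated step is a 3.1-fold higher number from compound 3 to compound 4 (0.50 log units; beyond the scatter). In this assay compound 4 is expected to give about 30000 nM, likely between 8000 nM and 150000 nM.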

Compound 4, half-maximal inhibitory concentration: 2630 nM
The estimate for compound 4 lay 11-fold (1.06 log units) above the measured number; the measured number lies below the stated range.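

In this assay, putting chloro in place of fluoro on the ring that carries the hydroxy group gave a 3.6-fold lower number from compound 3 to compound 4 (0.56 log units; beyond the scatter), which is a modest gain in strength, whereas the same kind of swap on the other core had made the number much higher. The swap therefore did not carry over from one core to the other in these compounds, in either direction or size: the same change on two cores in this assay, a 21-fold higher number (1.32 log units; beyond the scatter) from compound 2 to compound 1 and a 3.6-fold lower number (0.56 log units; beyond the scatter) from compound 3 to compound 4, 76-fold (1.88 log units) apart, beyond the scatter of two such steps This does not show why the two results part, since the two swaps sit on different rings, with the new chloro in compound 4 ortho to a hydroxy group, and the cores differ as well, so the place of the swap and the rest of the molecule cannot be told apart from just two pairs.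

Going by these compounds, it remains open whether a bromo or a methyl group in the place of the chloro of compound 4 would keep the lower number. Also open, on these data alone, is whether the swap on the 4-fluoro-3-hydroxyphenyl ring would go the same way if a methoxy group stood in place of the hydroxy group, which would help show whether that group matters for the result.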